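Methyl to chloro swap on the amide-bearing ring

This account rests on a few compounds, and the source may have more. Where it says the series, first, only, none or still open, it means among the compounds named here.

Compound 1 `CCNC(=O)c1ccc(-c2cc3nnn(C4CCN(c5ncc(CC)cn5)CC4)c3cn2)c(C)c1` and compound 2 `CCNC(=O)c1ccc(-c2cc3nnn(C4CCN(c5ncc(CC)cn5)CC4)c3cn2)c(Cl)c1` share one core and differ in a single spot: chloro in place of methyl on an aromatic carbon. In a functional assay on HEK293 cells for agonist activity at Glucose-dependent insulinotropic receptor (Homo sapiens), read by HTRF and cAMP accumulation, with a stated time of 30 min (a lower number here means that less compound is needed, a higher number that more compound is needed for the effect), compound 1 gives 19 nM, and compound 2 gives 13 nM. The swap made a 1.5-fold lower number from compound 1 to compound 2 (0.16 log units; within the scatter), so the two values cannot be told apart in order.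

Compound 3 `CCNC(=O)c1ccc(-c2cc3nnn(C4CCN(c5ncc(CC)cn5)CC4)c3cn2)cc1C` has the same atoms as compound 1, joined differently; the difference between the two cores is not broken down here. In this assay compound 3 gives 18 nM, which sits close to compound 1 and to compound 2 alike.

Compound 4 `CCNC(=O)c1ccc(-c2cc3nnn(C4CCN(c5ncc(CC)cn5)CC4)c3cn2)cc1Cl` is not yet measured and arises from compound 3 by chloro in place of methyl on an aromatic carbon. Within the data shown here, this is the same kind of change as the one from compound 1 to compound 2, not the same change: in compound 2 the chloro stands on an aromatic carbon ortho to a large group and meta to an ethylcarbamoyl group, whereas in compound 4 it stands ortho to an ethylcarbamoyl group and meta to a large group.

For compound 4 in this assay the step from compound 3 is expected to be a 1.4-fold lower number from compound 3 to compound 4 (0.14 log units; within the scatter), set beside a 1.5-fold lower number from compound 1 to compound 2 (0.16 log units; within the scatter). This expectation rests only on that one earlier pair and on compound 3, whose value of 18 nM lies close to compound 1. Compound 4 is therefore estimated at 13 nM, with an expected range from 6 nM to 28 nM.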

Compound 4, half-maximal effective concentration in the Glucose-dependent insulinotropic receptor assay: 18 nM
Compound 4: the middle estimate sits 1.4-fold (0.14 log units) below what was measured; the measured number falls inside the stated range.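

In the Glucose-dependent insulinotropic receptor assay compound 3 gives 18 nM and compound 4 gives 18 nM. In the Glucose-dependent insulinotropic receptor assay, where the new pair gives no change at the digits printed from compound 3 to compound 4 (within the scatter), chloro in place of methyl reads alike on the two cores, though two pairs cannot show that the change would read the same on any further core: the same change on two cores in the Glucose-dependent insulinotropic receptor assay, a 1.5-fold lower number (0.16 log units; within the scatter) from compound 1 to compound 2 and no change at the digits printed (within the scatter) from compound 3 to compound 4, 1.5-fold (0.16 log units) apart, within the scatter of two such steps

In a physicochemical assay for solubility, read by HPLC, in phosphate buffer, measured as thermodynamic solubility, with a stated time of 24 h, at pH 6.8 (a higher number here means a more soluble compound, a lower number a less soluble compound), compound 3 gives 1790 nM.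

In the physicochemical assay compound 4 gives < 160 nM, which stands at a limit, not at a number: the limit of < 160 nM in the physicochemical assay, at which 1 of the 2 values shown sits.

From the compounds shown here alone, in the physicochemical assay the same change gives an at least 11-fold lower number from compound 3 to compound 4 (1.04 log units; beyond the scatter), a large step that stands on this one core, so whether it carries to the core of compound 1 stays open.

Left open is how a fluoro, a methoxy or a nitrile on the aromatic carbon ortho to an ethylcarbamoyl group would read in the Glucose-dependent insulinotropic receptor assay and in the physicochemical assay, set against the methyl of compound 3 and the chloro of compound 4. Also open, going by these compounds, is whether an amine or a carboxylic acid in place of the ethylcarbamoyl group would leave the readings of the Glucose-dependent insulinotropic receptor assay where compound 3 and compound 4 stand.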